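The source may hold more compounds than are shown below. What is called first, only, known or untested is meant among the compounds shown, and "the series" means these compounds.

Measured so far in a functional assay on U-87MG ATCC cells for antiproliferative activity against U-87 MG (Homo sapiens), read by MTT assay, with a stated time of 48 h, tested at 100 uM; a higher number here means a weaker effect of the compound at the concentration tested, a lower number a stronger effect:
- compound 1 `COc1ccc(-c2nc(C)c(C(=O)CSc3nc(-c4ccc(Cl)cc4)c(C#N)c(=O)[nH]3)s2)cc1`, 2.85%
- compound 2 `Cc1nc(-c2ccc(Cl)cc2)sc1C(=O)CSc1nc(-c2ccc(Cl)c(Cl)c2)c(C#N)c(=O)[nH]1`, 36.5%
- compound 3 `Cc1nc(-c2ccccc2)sc1C(=O)CSc1nc(-c2ccc(Cl)c(Cl)c2)c(C#N)c(=O)[nH]1`, 24.4%

Compound 2 stands highest of the three numbers; the nearest is compound 3 and the furthest compound 1, both beyond the scatter. Compound 4 `COc1ccc(-c2nc(SCC(=O)c3sc(-c4ccc(Cl)cc4)nc3C)[nH]c(=O)c2C#N)cc1OC` differs from compound 2 in one place: 3,4-dimethoxyphenyl in place of 3,4-dichlorophenyl on an aromatic carbon. For the measured compounds named here, the only step measured, a number 12.1 percentage points lower from compound 2 to compound 3 (beyond the scatter), is on the same ring but removes a chloro; nothing here compares methoxy against chloro at that position. Going by the values given here, compound 1, the sole methoxy-bearing compound, gives the lowest number, but its methoxy sits elsewhere. A lower number than compound 2 is therefore expected, yet with wide uncertainty: compound 4 is estimated at 22%, range 4% to 42%, a step of a number 14.5 percentage points lower from compound 2 to compound 4 (beyond the scatter).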

Compound 4, a percentage reported as activity, at one concentration (the size of the read-out at that concentration, not a potency): 18.7%
Compound 4: the middle estimate sits 3.3 percentage points above what was measured; low and high end bracket the measured number.
By their numbers in this assay, from the lowest: compound 1; then compounds 4 and 3 (each within the scatter of the next); then compound 2.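

Here, 3,4-dimethoxyphenyl in place of 3,4-dichlorophenyl on the aromatic carbon ortho to a cyano group gives, in this assay, a number 17.8 percentage points lower from compound 2 to compound 4 (beyond the scatter). For the compounds shown here, this is the first direct comparison of methoxy against chloro on this ring, and the exchange moves the read-out toward a stronger effect at the concentration tested. Nothing available explains the step.

Open: whether a single methoxy would account for the step, since both groups change together in this pair. As far as these compounds go, also open: how an amine or a carboxylic acid on this ring would read.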